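Inverting the stereocentre from compound 2 to compound 3

The compounds below may be only part of what the source reports. "The series", "measured", "known", "first", "only" and "open" are said of these compounds alone.

In an ADME assay on HOS cells (Homo sapiens) for cytotoxicity (a lower number here means that less compound is tolerated, a higher number that more compound is tolerated), compound 1 `CN1CCN(c2cccc3nc(CN(C)C4CCCc5cccnc54)[nH]c23)CC1` gives 14000 nM and compound 2 `CN1CCN(c2cccc3nc(CN(C)[C@H]4CCCc5cccnc54)[nH]c23)CC1` gives 12500 nM as the half-maximal cytotoxic concentration. Within the data shown here, compound 2 therefore stands within the scatter of the only other number.

Compound 3 `CN1CCN(c2cccc3nc(CN(C)[C@@H]4CCCc5cccnc54)[nH]c23)CC1` has the same atoms and bonds as compound 2, and the one difference is the two compounds have the same atoms and bonds and differ only in configuration as drawn: 1 of 1 stereo elements differ; a stereocentre at a saturated ring carbon is drawn S in compound 2 and R in compound 3 at a stereocentre on a saturated ring carbon, drawn S in compound 2 and R in compound 3.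

Among the measured compounds shown here, one measured step bears on this stereocentre: a 1.1-fold lower number from compound 1 to compound 2 (0.05 log units; within the scatter) and it lies within the scatter. All that separates that pair is the fact that one of compounds 1 and 2 is drawn with a defined configuration and the other without, at the place where they differ and the R drawing has no measurement of its own yet.

Given the small size of a 1.1-fold lower number from compound 1 to compound 2 (0.05 log units; within the scatter) no step beyond the scatter is expected in this assay and neither direction is favoured. The expected change is a 1.1-fold higher number from compound 2 to compound 3 (0.03 log units; within the scatter) as an estimate only. Compound 3 is expected at 13500 nM with an estimated range from 6500 nM to 28000 nM for this measurement.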

Compound 3, half-maximal cytotoxic concentration: 12300 nM
Estimate against measurement, compound 3: 1.1-fold (0.04 log units) above; the measured number falls inside the stated range.
By their numbers in this assay, from the lowest: compounds 3, 2 and 1 (each within the scatter of the next).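

Read directly in this assay, the two defined drawings at the saturated ring carbon give a 1.0-fold lower number from compound 2 to compound 3 (0.01 log units; within the scatter), so this read-out does not separate S from R at this position, and the comparison is a clean one: the fact that compounds 2 and 3 differ only in the configuration as drawn. The drawing without a configuration does not stand apart from the R drawing either, with a 1.1-fold lower number from compound 1 to compound 3 (0.06 log units; within the scatter), which matches the earlier reading of a 1.1-fold lower number from compound 1 to compound 2 (0.05 log units; within the scatter). Until now only the S drawing had a measured comparison, and the R drawing could have behaved differently; in this assay, all three drawings now lie within the scatter of one another.

Going by these compounds, all three compounds share every other atom and bond, so it remains open whether configuration at this carbon stays without consequence in this assay once the rest of the structure changes. A carboxylic acid or a longer chain on the shared core would test this, and each defined drawing would then need its own reading, as the present result holds only for these three compounds.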